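The compounds below may be only part of what the source reports. "The series", "measured", "known", "first", "only" and "open" are said of these compounds alone.

Measured so far in a physicochemical assay for lipophilicity, at pH 7.4; on this read-out lower numbers stand for lower lipophilicity and higher numbers for higher lipophilicity:
compound 1 `COc1ccc(-c2c(C)nc3c(NCc4ccc(C(N)=O)cc4)cc(C)cn23)cc1OC` gives 4.3
compound 2 `COc1ccc(-c2c(C)nc3c(NCc4cccnc4)cc(C)cn23)cc1OC` gives 4.9
compound 3 `COc1ccc(-c2c(C)nn3c(NCc4ccc(C(N)=O)cc4)nc(C)cc23)cc1OC` gives 4.8

Compound 1 and compound 3 carry the same side chain on different cores; the difference between the two cores is not broken down here. Compound 3 sits within the scatter of compound 2 and beyond it relative to compound 1. One change is seen twice in the set. From compound 1 to compound 2 it reads (pyridin-3-yl in place of 4-carbamoylphenyl on a saturated chain carbon bound to a nitrogen on an aromatic ring), and in this assay it gave a number 0.60 log units higher from compound 1 to compound 2 (beyond the scatter). Compound 4 `COc1ccc(-c2c(C)nn3c(NCc4cccnc4)nc(C)cc23)cc1OC` is not yet measured; from compound 3 it carries pyridin-3-yl in place of 4-carbamoylphenyl on a saturated chain carbon bound to a nitrogen on an aromatic ring, at the same place, so the same change. The step to compound 4 in this assay is expected to be a number 0.60 log units higher from compound 3 to compound 4 (beyond the scatter), resting on a number 0.60 log units higher from compound 1 to compound 2 (beyond the scatter). Compound 4 is therefore estimated at 5.4, expected between 5 and 5.8.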

Compound 4, distribution coefficient: 5.5
Estimate against measurement, compound 4: 0.10 log units below; the measured number falls inside the stated range.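

In this assay, pyridin-3-yl in place of 4-carbamoylphenyl gave a number 0.70 log units higher from compound 3 to compound 4 (beyond the scatter) on one core and a number 0.60 log units higher from compound 1 to compound 2 (beyond the scatter) on the other, so the change carried over between these two cores in direction and at a modest size. This rests on two pairs only and says nothing about any further core or about other groups at this place. No measurement offered here explains the rise or why it recurs on both cores.

Open, as far as these compounds go, is how much of the step goes with the carbamoyl group and how much with the ring, which a plain phenyl on the same carbon would separate. Also open, from the compounds shown here alone, is how a carboxylic acid or an amine in place of the carbamoyl group would read in this assay.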